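The compounds below may be only part of what the source reports. "The series", "measured", "known", "first", "only" and "open" are said of these compounds alone.

Compound 1, with the structure `CC(C)(C)OC(=O)N1CCC(O[C@H]2CC[C@H](Oc3ccc(S(C)(=O)=O)cc3)CC2)CC1`, is the reference point here. In a functional assay on isolated protein for agonist activity at Glucose-dependent insulinotropic receptor (Homo sapiens), read by HTRF and cAMP accumulation (on this read-out higher numbers stand for larger maximal responses and lower numbers for smaller maximal responses), compound 1 gives 115%, the top of the three numbers, though the two neighbours sit close. Compound 2, `CC(C)(C)OC(=O)N1CCC(O[C@H]2CC[C@H](Oc3ccc(S(C)(=O)=O)cc3F)CC2)CC1`, gives 113% in this assay, and compound 3, `CC(C)(C)OC(=O)N1CCC(O[C@H]2CC[C@H](Oc3ccc(S(C)(=O)=O)c(F)c3)CC2)CC1`, gives 106%. The step of a number 2 percentage points lower from compound 1 to compound 2 (within the scatter) and the step of a number 9 percentage points lower from compound 1 to compound 3 (within the scatter) both stay inside the usual scatter, so these two fluoro-for-hydrogen exchanges on an aromatic carbon left the maximal response essentially unchanged.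

Compound 4, `CC(C)(C)OC(=O)N1CCC(O[C@H]2CC[C@H](Oc3ccc(C#N)cc3)CC2)CC1`, has not yet been tested. It differs from compound 1 by cyano in place of methylsulfonyl on an aromatic carbon. Neither measured step concerns this kind of exchange; both only swap hydrogen for fluoro, so nothing measured speaks directly to what a cyano in place of methylsulfonyl does. Going by the values given here, since the only changes seen on this ring stayed within scatter, the expectation for compound 4 in this assay is a step of a number 10 percentage points lower from compound 1 to compound 4 (within the scatter), which is no clear change. Compound 4 is therefore estimated at 105%, with a range from 85% to 125%.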

Compound 4, largest response reached (Emax), in percent of the reference or control that the assay uses: 116%
Compound 4: the middle estimate sits 11 percentage points below what was measured; the range from low to high includes it.
By their numbers in this assay, from the lowest: compounds 3, 2, 1 and 4 (each within the scatter of the next).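

Going by these compounds alone, the 4-(methylsulfonyl)phenyl to 4-cyanophenyl change is the first one here that replaces the large group itself rather than a ring hydrogen, and in this assay it gives a number 1 percentage points higher from compound 1 to compound 4 (within the scatter). At this position, then, methylsulfonyl (4 heavy atoms, 2 hydrogen-bond acceptors) can be exchanged for cyano (2 heavy atoms, 1 hydrogen-bond acceptor) with no clear change in maximal response, so for these two compounds the sulfur-containing group is not required. No measurement is available to explain why the response holds across this exchange.

As far as these compounds go, whether an amine or a carboxylic acid at this position would hold the response as well remains open. Also open, from the compounds shown here alone, is whether a fluoro on the aromatic ring of compound 4 would leave the response as unchanged as it did on compound 1.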